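The source may report more compounds than this note shows. Statements on the series, on what has been measured and on what is new or still open speak of the compounds shown alone.

Compound 1 `CCCCCCCCNC1=CC(=O)C(C(C)(C)C)=CC1=O`: 65000 nM
Compound 2 `CCCCNC1=CC(=O)C(C[C@]2(C)[C@@H](C)CC[C@]3(C)C(C)=CCC[C@@H]23)=CC1=O`: > 100000 nM
Compound 3 `CCCCNC1=CC(=O)C(C(C)(C)C)=CC1=O`: 72000 nM

In a functional assay on NCI-H460 cells (Homo sapiens) for cytotoxicity, read by MTT assay, with a stated time of 72 h (on this read-out lower numbers stand for stronger inhibition and higher numbers for weaker inhibition), compound 1 gives 65000 nM and compound 3 gives 72000 nM. The step between them, a 1.1-fold higher number from compound 1 to compound 3 (0.04 log units; within the scatter), shows that shortening the chain on the amine nitrogen changes the read-out by less than the scatter. Compound 2, which joins a butylamino group on the shared core to a large bicyclic terpene, is different: for compound 2 the assay reports only a limit, > 100000 nM, not a number, so the result is known only as the limit of > 100000 nM in this assay, at which 1 of the 3 values shown sits.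

Compound 4 `CC1=CCC[C@H]2[C@](C)(CC3=CC(=O)C=CC3=O)[C@@H](C)CC[C@]12C` keeps the terpene and the core of compound 2 but not the amine: hydrogen in place of butylamino on a double-bonded ring carbon. For the measured compounds named here, no measured step bears directly on this change; the one step in hand, from compound 1 to compound 3, alters only the length of the chain on the nitrogen and stays within the scatter, so it gives no guide to removing the whole butylamino group. Starting from a limit, the direction of the step is open, and the estimate is correspondingly wide. The expected step is an at least 2.0-fold lower number from compound 2 to compound 4 (0.30 log units; that floor lies within the scatter). Compound 4 is estimated at 50000 nM, within a range from 8000 nM to 300000 nM.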

Compound 4, half-maximal inhibitory concentration: 24000 nM
Beside the measured number, compound 4's estimate is 2.1-fold (0.32 log units) above it; low and high end bracket the measured number.
By their numbers in this assay, from the lowest: compound 4; then compounds 1 and 3 (each within the scatter of the next). At a limit, above all of these: compound 2.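

In this assay, the step of a 1.1-fold higher number from compound 1 to compound 3 (0.04 log units; within the scatter) changed only the length of the chain on the nitrogen and left the read-out within the scatter. The new step goes further by removing the whole butylamino group from the double-bonded ring carbon and leaving hydrogen there, with the large terpene kept in place: an at least 4.1-fold lower number from compound 2 to compound 4 (0.61 log units; beyond the scatter). This is the first change shown at this position that lies beyond the scatter, so the presence of the butylamino group matters here in a way that its chain length did not, although compound 2 stands at a limit rather than a number and the true size of the step stays unknown: the limit of > 100000 nM in this assay, at which 1 of the 4 values shown sits.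

This rests on a single pair, and the compounds shown leave open whether hydrogen in place of butylamino would give a step of similar size on a core carrying the smaller group of compound 3 instead of the terpene. Also open, as far as these compounds go, is what a hydroxyl group or a methoxy group on that same ring carbon would give in this assay compared with hydrogen.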